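A few compounds are considered here, and "the series" means these few. Any claim that something is new, unique, unknown or untested is made for them only; others in the source may bear on it.

Compound 1, `Nc1ccccc1NC(=O)/C=C/c1ccc(CSc2ccc(Cl)cc2)cc1`, was examined in a functional assay on HeLa cells (Homo sapiens) for inhibition, read by CCK-8 assay, with a stated time of 72 h, tested at 2 uM; a higher number here means more inhibition of growth at the concentration tested, a lower number less inhibition of growth. In this assay compound 1 gives 1.94%, the lowest of the two numbers recorded. Within the data shown here, the only other measured compound, compound 2, `COc1ccc(SCc2ccc(C(=O)Nc3ccccc3N)cc2)cc1`, gives 35% in this assay, a number beyond the scatter above that of compound 1; the two structures differ in more than one place, so their values are compared only as they stand.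

Compound 3, `Nc1ccccc1NC(=O)/C=C/c1ccc(CSc2cccc3ccccc23)cc1`, has not yet been measured in this assay. It differs from compound 1 in a single place: naphthalen-1-yl in place of 4-chlorophenyl on a sulfur. The two compounds share the same core, and only the group on the sulfur changes.

Among the measured compounds shown here, no step between measured compounds is available to guide the expectation, so the estimate rests on the low value of compound 1 and on the larger aryl group entering. The step is expected to be a modest rise, a number 13.1 percentage points higher from compound 1 to compound 3 (beyond the scatter), plausibly reaching just beyond the scatter but uncertain in size. Compound 3 is therefore estimated to give 15% in this assay, within a range from 0% to 40%.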

Compound 3, percent growth inhibition at one concentration: 20.6%
Compound 3: middle estimate off by 5.6 percentage points, on the low side; low and high end bracket the measured number.
By their numbers in this assay, from the lowest: compound 1; then compound 3; then compound 2.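

Naphthalen-1-yl in place of 4-chlorophenyl on a sulfur gives the first single-place comparison among these compounds, and in this assay it produces a number 18.7 percentage points higher from compound 1 to compound 3 (beyond the scatter). The group at this position therefore affects the read-out, which the earlier pair of compounds, differing in more than one place, could not show. Here, two six-membered aromatic rings of carbon in place of one, with the sulfur still bound to its saturated chain carbon, retain growth inhibition and raise it modestly, although this rests on one step and sets no trend. The data shown offer no measurement that accounts for this rise.

The step removes the chlorine and adds ring atoms at once, so the compounds shown do not separate these two changes, and an unsubstituted phenyl group on the sulfur would be needed to tell them apart. Also open, on these data alone, is how this position would respond to the isomeric naphthalen-2-yl group, or to a group of a different kind, such as a carboxylic acid or an amine on the aromatic ring.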